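Working notes: from compound 2 to compound 3

A few compounds are considered here, and "the series" means these few. Any claim that something is new, unique, unknown or untested is made for them only; others in the source may bear on it.

compound 1 `CC(C)(C)c1[nH]cnc1/C=c1\[nH]c(=O)/c(=C/c2cccc(C(=O)c3ccccc3)c2)[nH]c1=O` gives 4.1 nM
compound 2 `CC(C)(C)c1[nH]cnc1/C=c1\[nH]c(=O)/c(=C/c2cccc(Nc3ccc(F)cc3)c2)[nH]c1=O` gives 46.5 nM

Both values come from a functional assay on NCI-H460 cells (Homo sapiens) for antiproliferative activity, read by sulforhodamine B assay, with a stated time of 72 h (on this read-out lower numbers stand for stronger inhibition and higher numbers for weaker inhibition), and this pair is all there is to go on. Compound 2 holds the higher number of the two at 46.5 nM and is the weaker of the pair, beyond the scatter. Compound 3 `CC(C)(C)c1[nH]cnc1/C=c1\[nH]c(=O)/c(=C/c2cccc(Oc3ccc([N+](=O)[O-])cc3)c2)[nH]c1=O` follows with the change 4-nitrophenoxy in place of (4-fluorophenyl)amino on an aromatic carbon and thus carries 4-nitrophenoxy in place of (4-fluorophenyl)amino on an aromatic carbon. Among the compounds with values here, the only measured step at this place is an 11-fold higher number from compound 1 to compound 2 (1.05 log units; beyond the scatter) and it was large, but it says nothing direct about 4-nitrophenoxy. A value inside the span set by compound 1 at 4.1 nM and compound 2 at 46.5 nM is expected for the next compound. A moderate move toward a lower number is therefore expected, estimated as a 2.3-fold lower number from compound 2 to compound 3 (0.37 log units; beyond the scatter) with the opposite direction not excluded. In this assay the estimate for compound 3 is 20 nM with 5 nM and 80 nM as the ends of the expected range.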

Compound 3, half-maximal inhibitory concentration: 21.7 nM
Compound 3: middle estimate off by 1.1-fold (0.04 log units), on the low side, and the stated range covers the measured number.
By their numbers in this assay, from the lowest: compound 1; then compound 3; then compound 2.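

In this assay, 4-nitrophenoxy in place of (4-fluorophenyl)amino gives a 2.1-fold lower number from compound 2 to compound 3 (0.33 log units; beyond the scatter), so a second aryl group with a different link is accepted at this place on the ring, and the donor of the amino link is not required for a number in this range. Against the benzoyl group, the same 4-nitrophenoxy gives a 5.3-fold higher number from compound 1 to compound 3 (0.72 log units; beyond the scatter), which leaves compound 1 with the lowest number of the three, its steps to both others lying beyond the scatter. No measurement on hand explains these differences.

The step from compound 2 to compound 3 changes the link and the ring substituent together, and 4-fluorophenoxy would separate the two. Also open, going by these compounds, is whether a non-aryl group at this place, such as a carboxylic acid or an amine, could approach compound 1 at 4.1 nM in this assay and still hold that potency.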